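The source may hold more compounds than are shown below. What is called first, only, known or untested is meant among the compounds shown, and "the series" means these compounds.

Measured in an ADME assay on MCF-10A cells (Homo sapiens) for inhibition, with a stated time of 48 h; on this read-out lower numbers stand for stronger inhibition and higher numbers for weaker inhibition:
- Compound 1 `Cc1ccccc1-c1noc([C@@H]2CCCN2C(=O)Nc2ccc(Cl)cc2)n1`: > 50000 nM, a limit of the assay.
- Compound 2 `O=C(Nc1ccc(Cl)cc1)N1CCC[C@H]1c1nc(-c2ccccc2Cl)no1`: > 50000 nM, a limit of the assay.
- Compound 3 `O=C(Nc1ccc(Cl)cc1)N1CCC[C@H]1c1nc(-c2cccc(F)c2)no1`: > 50000 nM, a limit of the assay.

Compound 3 therefore has no exact number in this assay, only a limit, and it has no neighbour with an exact number either. The whole set sits in one place: the limit of > 50000 nM in this assay, at which 3 of the 3 values shown sit.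

The next compound is compound 4 `O=C(Nc1ccc(Cl)cc1)N1CCC[C@H]1c1nc(-c2cccc(Br)c2)no1`. It keeps the shared core of compound 3 and changes one group: bromo in place of fluoro on an aromatic carbon, on a six-membered aromatic ring of carbon only, meta to a large group (bromo in place of fluoro on an aromatic carbon).

The measured steps that bear on this also change the substituted aromatic ring: a step that the two limits leave unreadable from compound 1 to compound 2, a step that the two limits leave unreadable from compound 1 to compound 3 and a step that the two limits leave unreadable from compound 2 to compound 3. None of them has a readable size, so they give no measured effect to carry over. They do show that all three substituted rings tried so far end at the same limit.

No step beyond the usual scatter is therefore expected, and no direction can be given. The expected step is a number no higher from compound 3 to compound 4 (the limit leaves the size open). Another limit is the most likely report. For compound 4 the estimated value is 50000 nM, with an expected range of 25000 nM to 100000 nM.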

Compound 4, half-maximal inhibitory concentration: > 50000 nM
Compound 4: a limit, no number; the forecaster's own chance of this, stated with the estimate: 85%; the middle value lies on the limit itself.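

Going by these compounds alone, compound 4 gives only a limit in this assay, and compound 1, compound 2 and compound 3 give limits too, so no step to compound 4 can be read. All the results fall in one place: the limit of > 50000 nM in this assay, at which 4 of the 4 values shown sit.

The compounds shown leave open how strongly any of them inhibits and whether changing the substituted aromatic ring alters that.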